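Swapping a Halogen on the Fused Ring of a Sulfone

The compounds below may be only part of what the source reports. "The series", "measured", "known", "first", "only" and "open" are said of these compounds alone.

The series collects four sulfones built on one shared core. Compound 1 `O=S(=O)(c1ccc(F)cc1)c1cnc2cc(F)c(Cl)cc2c1-c1ccc(Cl)cc1` and compound 2 `O=S(=O)(c1ccc(F)cc1)c1cnc2cc(Cl)c(F)cc2c1-c1ccc(Cl)cc1` each carry both a fluoro and a chloro on the fused carbocyclic ring. In an assay (strain Sprague-Dawley) for displacement of a labelled ligand from metabotropic glutamate receptor 5 (Rattus norvegicus), with a stated time of 60 min (on this read-out lower numbers stand for stronger inhibition and higher numbers for weaker inhibition), compound 1 gives "not determined" (no result reported) and compound 2 gives "not determined" (no result reported), so they stand in the set as structures only. Compound 3 `O=S(=O)(c1ccc(F)cc1)c1cnc2cc(F)ccc2c1-c1ccc(Cl)cc1` carries a single fluoro there. In this assay compound 3 gives 38.6 nM, the only number shown in the whole set; with the other two entries blank, it has no neighbour against which to judge how far any step might move the read-out.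

Compound 4 `O=S(=O)(c1ccc(F)cc1)c1cnc2cc(Cl)ccc2c1-c1ccc(Cl)cc1` is the one still to be measured. It differs from compound 3 by chloro in place of fluoro on an aromatic carbon. Among the measured compounds shown here, no measured pair in this set shows what such a swap does, so the writer has no basis for expecting a step beyond the scatter in either direction in this assay. For compound 4 the estimate is therefore 35 nM, with a range from 12 nM to 110 nM, which means an expected step from compound 3 to compound 4 of a 1.1-fold lower number from compound 3 to compound 4 (0.04 log units; within the scatter), a change that would sit within the usual scatter of repeated measurements.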

Compound 4, inhibition constant: 110 nM
Compound 4: the middle estimate sits 3.1-fold (0.50 log units) below what was measured, and the stated range covers the measured number.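

Chloro in place of fluoro on this aromatic carbon gives a 2.8-fold higher number from compound 3 to compound 4 (0.45 log units; beyond the scatter) in this assay, the first measured step in the set. The position is therefore not indifferent to which of these two halogens it carries: although the change is modest, compound 3 with fluoro binds more strongly than compound 4 with chloro, something that a single value could not reveal. Nothing shown here explains the step, which stands as an observation without a measured cause.

As far as these compounds go, compounds 1 and 2 carry both halogens on the fused ring but have no number, so all steps involving them cannot be read, and it remains open how a second halogen on that ring would shift the read-out. The compounds shown also leave open how a methoxy group, a nitrile or an amine would compare with fluoro and chloro on this aromatic carbon, and whether the same halogen swap would give a similar step with a different group in place of the chloro on the phenyl ring of the shared core.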